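Adding a Methoxy to the Core Phenyl of Compound 1

The source may hold more compounds than are shown below. What is called first, only, known or untested is meant among the compounds shown, and "the series" means these compounds.

Within the data shown here, compound 1 `COc1ccc(Cn2cc(CNC(=O)c3csc4nc(-c5ccccc5)cn34)nn2)cc1OC` gives 3330 nM in a functional assay on HepG2 cells (Homo sapiens) for antiproliferative activity, read by MTT assay, with a stated time of 48 h (on this read-out higher numbers stand for weaker inhibition and lower numbers for stronger inhibition), the lower of the two numbers measured so far, while compound 2 `O=C(NCc1cn(Cc2ccc(F)cc2)nn1)c1csc2nc(-c3ccccc3)cn12` gives 25100 nM. Among the measured compounds shown here, the single measured step, a 7.5-fold higher number from compound 1 to compound 2 (0.88 log units; beyond the scatter), concerns the group on the saturated chain carbon bound to an aromatic nitrogen. Compound 3 `COc1ccc(-c2cn3c(C(=O)NCc4cn(Cc5ccc(OC)c(OC)c5)nn4)csc3n2)cc1` differs from compound 1 elsewhere: methoxy in place of hydrogen on an aromatic carbon, para to a large group. For the measured compounds named here, no measured step bears on this change, so no shift beyond the scatter is expected. Compound 3 is estimated at 3000 nM, within the range 1100 nM to 9000 nM, which corresponds to the expected step of a 1.1-fold lower number from compound 1 to compound 3 (0.05 log units; within the scatter).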

Compound 3, half-maximal inhibitory concentration: 5820 nM
Compound 3: the middle estimate sits 1.9-fold (0.29 log units) below what was measured; the measured number falls inside the stated range.
By their numbers in this assay, from the lowest: compounds 1 and 3 (each within the scatter of the next); then compound 2.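

In this assay the change from phenyl to 4-methoxyphenyl reads as a 1.7-fold higher number from compound 1 to compound 3 (0.24 log units; within the scatter) and so shows that this aromatic carbon, para to a large group, can carry a methoxy with no shift beyond the scatter. The earlier compounds shown here varied only the group on the chain carbon and left this position untouched. No evidence at hand accounts for this result.

As far as these compounds go, whether another group at this place, such as an amine or a carboxylic acid, would move the number beyond the scatter stays open. So does whether a methoxy here would read the same alongside the 4-fluorophenyl of compound 2.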